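The compounds below may be only part of what the source reports. "The series", "measured", "known", "first", "only" and "open" are said of these compounds alone.

Measured compounds:
compound 1 `Cc1cncc(-c2ccc3[nH]c(=O)nc(-c4ccccc4)c3c2)c1` with > 50000 nM
compound 2 `O=c1nc(-c2ccccc2)c2cc(-c3cnc4ccccc4c3)ccc2[nH]1` with > 50000 nM

Both values come from an ADME assay on THP-1 cells (Homo sapiens) for cytotoxicity, read by MTT assay, with a stated time of 72 h; a lower number here means that less compound is needed, a higher number that more compound is needed for the effect. For compound 1 the value > 50000 nM is a limit of the assay, not a number. For compound 2 the value > 50000 nM is likewise a limit. Compound 1 therefore stands where the whole set stands, at the limit of > 50000 nM in this assay, at which 2 of the 2 values shown sit, so no ordering between compound 1 and compound 2 can be read from this assay.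

The unmeasured compound 3 `O=c1nc(-c2ccccc2)c2cc(-c3cc[nH]n3)ccc2[nH]1` differs from compound 1 by 1H-pyrazol-3-yl in place of 5-methylpyridin-3-yl on an aromatic carbon. No step between measured compounds is available, so the size of the change cannot be calibrated from the shown data. Given that compound 1 sits at the limit of > 50000 nM in this assay, at which 2 of the 2 values shown sit, and compound 2 at the same limit, compound 3 is expected to stay at that limit too, giving an estimated step of a number no higher from compound 1 to compound 3 (the limit leaves the size open) of no measurable size. Compound 3 is estimated at 50000 nM, within 20000 nM to 100000 nM.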

Compound 3, half-maximal effective concentration: > 50000 nM
Compound 3: a limit, no number; the forecaster's own chance of this, stated with the estimate: 85%; the middle value lies on the limit itself.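

In this assay, among these compounds, compound 3 gives > 50000 nM as a limit, not a number, and compound 1 also sits at a limit, so no step between compound 1 and compound 3 can be read: the limit of > 50000 nM in this assay, at which 3 of the 3 values shown sit. The compounds shown leave open whether 1H-pyrazol-3-yl and 5-methylpyridin-3-yl differ at all in this assay.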